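The compounds below may be only part of what the source reports. "The series", "measured", "known", "first", "only" and "open" are said of these compounds alone.

Measured so far, in a functional assay on HeLa S3 cells (Homo sapiens) for antiproliferative activity, read by XTT assay, with a stated time of 72 h; on this read-out lower numbers stand for stronger inhibition and higher numbers for weaker inhibition:
Compound 1 `COc1ncnc2c1c(-c1ccoc1)cn2[C@@H]1O[C@H](CO)[C@@H](O)[C@H]1O` gives 1790 nM.
Compound 2 `COc1ncnc2c1c(-c1cccs1)cn2[C@@H]1O[C@H](CO)[C@@H](O)[C@H]1O` gives 1760 nM.

On these two numbers compound 2 cannot be set apart from compound 1: the step of a 1.0-fold lower number from compound 1 to compound 2 (0.01 log units; within the scatter) falls within the scatter, so both compounds stand at essentially the same level.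

Compound 3 `COc1ncnc2c1c(-c1ccccc1)cn2[C@@H]1O[C@H](CO)[C@@H](O)[C@H]1O` has not been measured. The change from compound 2 is phenyl in place of thiophen-2-yl on an aromatic carbon. For the measured compounds named here, only one measured step bears on it, a 1.0-fold lower number from compound 1 to compound 2 (0.01 log units; within the scatter), where one five-membered aromatic ring with one hetero atom replaced another and the number stayed put. Going by the values given here, no measured step replaces such a ring with a phenyl, so the evidence is indirect. Since the shared core tolerated that exchange without a shift beyond the scatter, compound 3 is expected to move by no more than a 1.1-fold higher number from compound 2 to compound 3 (0.06 log units; within the scatter), direction uncertain.

Compound 3 is thus estimated at 2000 nM, with a range from 800 nM to 5000 nM.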

Compound 3, half-maximal inhibitory concentration: > 20000 nM
Compound 3: no number, only a limit; the forecaster's own chance of this, stated with the estimate: 5%; at least 10-fold (1.00 log units) between middle value and limit.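

In this assay, the tolerance seen between the two five-membered aromatic rings does not extend to every aromatic group at this position on the shared core: phenyl in place of thiophen-2-yl gives an at least 11-fold higher number from compound 2 to compound 3 (1.05 log units; beyond the scatter), and phenyl in place of furan-3-yl gives an at least 11-fold higher number from compound 1 to compound 3 (1.04 log units; beyond the scatter). Among these three compounds, only the one with a six-membered aromatic ring of carbon only lacks a measured number. The reading for compound 3 is a limit and not a number, so the full size of both steps stays unknown: the limit of > 20000 nM in this assay, at which 1 of the 3 values shown sits.

The compounds shown do not separate the change in ring size from the loss of the ring hetero atom. As far as these compounds go, what a pyridin-3-yl ring, which has six members and keeps a hetero atom, would give at this position remains open, as does the effect of a simple amine there.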